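Series notes: aryl amide swap on the shared core

A few compounds are considered here, and "the series" means these few. Any claim that something is new, unique, unknown or untested is made for them only; others in the source may bear on it.

Compound 1 `O=C(NCN1CCC(c2cccc[n+]2[O-])CC1)c1cnccc1Cl` and compound 2 `O=C(CN1CCC(c2cccc[n+]2[O-])CC1)Nc1cccc(-c2ccccc2)c1` have been measured in a functional assay on HEK293 cells for agonist activity at D(4) dopamine receptor (Homo sapiens), read by FLIPR; a lower number here means a smaller maximal response, a higher number a larger maximal response. Compound 1 gives 44%, the lower of the two numbers, and compound 2 gives 75%, a gap beyond the scatter. Within the data shown here, no step between compounds differing in one place has been measured yet. Compound 3 `O=C(NCN1CCC(c2cccc[n+]2[O-])CC1)c1cc(Cl)cc(Cl)c1` is not yet measured; it differs from compound 1 as follows: 3,5-dichlorophenyl in place of 4-chloropyridin-3-yl on a carbonyl carbon. Among the measured compounds shown here, with no measured step of this kind to lean on, only a small shift is expected, within or just beyond the scatter and upward if anything; the expected step is a number 6 percentage points higher from compound 1 to compound 3 (within the scatter). For compound 3 the estimate is 50%, within the range 30% to 75%.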

Compound 3, largest response reached (reported as efficacy), in percent of the reference or control that the assay uses: 64%
Beside the measured number, compound 3's estimate is 14 percentage points below it, within the range that was stated.
By their numbers in this assay, from the lowest: compound 1; then compound 3; then compound 2.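

In this assay, the group on the carbonyl carbon now has its first measured step: 3,5-dichlorophenyl in place of 4-chloropyridin-3-yl gives a number 20 percentage points higher from compound 1 to compound 3 (beyond the scatter) on the shared core. The maximal response at this position therefore responds to the aryl group alone, with the rest of compound 1 unchanged. Nothing at hand explains this step.

The change removes the ring nitrogen and adds a second chlorine together, so the compounds shown do not separate the two. Going by these compounds, how an unsubstituted phenyl or a methoxy group on the ring would fare at this position remains open.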